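Diisopropylamino in place of diethylamino on the free alcohol

A few compounds are considered here, and "the series" means these few. Any claim that something is new, unique, unknown or untested is made for them only; others in the source may bear on it.

Compound 3 `CCCCCCCCCCCCCC[C@H](O)[C@H](CN(CC)CC)NC(=O)OC(C)(C)C` gives 18.5% in a functional assay on A549 cells (Homo sapiens) for antiproliferative activity, read by sulforhodamine B assay, with a stated time of 48 h, tested at 10 uM (on this read-out higher numbers stand for more inhibition at the one concentration tested (going by the name of the read-out) and lower numbers for less inhibition), the lowest of the three numbers, though all three lie within the usual scatter of one another: compound 1 `CCCCCCCCCCCCCC[C@H](OCOC)[C@H](CN(CC)CC)NC(=O)OC(C)(C)C` gives 27.5% and compound 2 `CCCCCCCCCCCCCC[C@H](OCOC)[C@H](CN(C(C)C)C(C)C)NC(=O)OC(C)(C)C` gives 22.6%. The step of a number 9 percentage points lower from compound 1 to compound 3 (within the scatter) is within the scatter. Compound 4 `CCCCCCCCCCCCCC[C@H](O)[C@H](CN(C(C)C)C(C)C)NC(=O)OC(C)(C)C` differs from compound 3 in one place: diisopropylamino in place of diethylamino on a saturated chain carbon, two bonds along the chain from an amide-type nitrogen. The same change is seen once already, as a number 4.9 percentage points lower from compound 1 to compound 2 (within the scatter), within the scatter. Compound 4 is therefore expected to show a step of a number 3.5 percentage points lower from compound 3 to compound 4 (within the scatter), i.e. no change beyond the scatter, if anything a slightly lower number. For compound 4 the estimate is 15%, with a range from 5% to 25%.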

Compound 4, a percentage reported as inhibition, at one concentration (the size of the read-out at that concentration, not a potency): 22.9%
For compound 4 the middle estimate is 7.9 percentage points below the measured one; the range from low to high includes it.
By their numbers in this assay, from the lowest: compounds 3, 2, 4 and 1 (each within the scatter of the next).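

On the free alcohol, diisopropylamino in place of diethylamino gives a number 4.4 percentage points higher from compound 3 to compound 4 (within the scatter) in this assay, so the change on a saturated chain carbon, two bonds along the chain from an amide-type nitrogen, now reads on two cores without a direction beyond the scatter: the same change on two cores in this assay, a number 4.9 percentage points lower (within the scatter) from compound 1 to compound 2 and a number 4.4 percentage points higher (within the scatter) from compound 3 to compound 4, 9.3 percentage points apart, within the scatter of two such steps
Hydrogen in place of methoxymethyl on the oxygen, now also read with diisopropylamino, gives a number 0.3 percentage points higher from compound 2 to compound 4 (within the scatter): the same change on two cores in this assay, a number 9 percentage points lower (within the scatter) from compound 1 to compound 3 and a number 0.3 percentage points higher (within the scatter) from compound 2 to compound 4, 9.3 percentage points apart, within the scatter of two such steps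
Neither change moves the number beyond the scatter in any pair shown.

Still open, from the compounds shown here alone, is whether morpholine in place of these dialkylamino groups would do so. The same holds for a free primary amine in place of the tert-butyl carbamate.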